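A third group on the shared core's aromatic nitrogen

The source may report more compounds than this note shows. Statements on the series, on what has been measured and on what is new or still open speak of the compounds shown alone.

- Compound 1 `C[C@@H]1O[C@@H](n2c3ccccc3c3c4c(c5c6ccccc6ccc5c32)C(=O)NC4=O)[C@H](O)[C@H](O)[C@H]1O`: 4500 nM
- Compound 2 `O=C1NC(=O)c2c1c1c3ccccc3ccc1c1c2c2ccccc2n1[C@H]1OC[C@@H](O)[C@@H](O)[C@H]1O`: 4800 nM

Among the compounds with values here, in a functional assay on MCF7 cells (Homo sapiens) for cytotoxicity (on this read-out higher numbers stand for weaker inhibition and lower numbers for stronger inhibition), compound 2 stands level with the only other measured compound, within the scatter. Compound 3 `O=C1NC(=O)c2c1c1c3ccccc3ccc1c1c2c2ccccc2n1[C@@H]1O[C@H](CO)[C@@H](O)[C@H](O)[C@H]1O` carries 3,4,5-trihydroxy-6-(hydroxymethyl)oxan-2-yl on that aromatic nitrogen: a group of 11 heavy atoms (6 carbon, 5 oxygen; one six-membered non-aromatic ring with 1 hetero atom) in place of a group of 9 heavy atoms (5 carbon, 4 oxygen; one six-membered non-aromatic ring with 1 hetero atom), on an aromatic nitrogen. Within the data shown here, the one measured step that bears on this, also an exchange of the group on that nitrogen, is a 1.1-fold higher number from compound 1 to compound 2 (0.03 log units; within the scatter). One small step is thin evidence, but no change beyond the scatter is expected. The expected step is a 1.1-fold lower number from compound 2 to compound 3 (0.03 log units; within the scatter). The estimate for compound 3 is 4500 nM, with an expected range from 1500 nM to 13000 nM.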

Compound 3, half-maximal inhibitory concentration: 6100 nM
For compound 3 the middle estimate is 1.4-fold (0.13 log units) below the measured one, within the range that was stated.
By their numbers in this assay, from the lowest: compounds 1, 2 and 3 (each within the scatter of the next).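

Compared with the group on compound 2, the larger 3,4,5-trihydroxy-6-(hydroxymethyl)oxan-2-yl group on the aromatic nitrogen gives, in this assay, a 1.3-fold higher number from compound 2 to compound 3 (0.10 log units; within the scatter). Putting it in place of 3,4,5-trihydroxy-6-methyloxan-2-yl gives a 1.4-fold higher number from compound 1 to compound 3 (0.13 log units; within the scatter). All three groups therefore read alike at this position, so exchanging methyl for hydroxymethyl on this ring leaves the number level. Nothing available explains this result. The compounds shown leave open whether an amine or a carboxylic acid on the ring, or a butyl chain in its place, would move the number beyond the scatter.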